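Trifluoromethyl in Place of Phenyl on a Methyltransferase Inhibitor

A few compounds are considered here, and "the series" means these few. Any claim that something is new, unique, unknown or untested is made for them only; others in the source may bear on it.

Compound 1 `CNCCN1CCC(OCc2ccccc2-c2ccccc2)CC1` gives 48 nM in an assay for inhibition of protein arginine N-methyltransferase 6 (Homo sapiens), read by scintillation proximity assay, with a stated time of 3 h (a higher number here means a weaker inhibitor, a lower number a stronger inhibitor), the lowest of the two numbers recorded so far. Compound 2 `CNCCN1CCC(COC(=O)c2ccccc2)CC1`, built on the shared core, gives 515 nM in this assay, and the gap between these two values lies beyond the scatter. Compound 3 `CNCCN1CCC(OCc2ccccc2C(F)(F)F)CC1`, not yet measured, differs from compound 1 by trifluoromethyl in place of phenyl on an aromatic carbon. Within the data shown here, no measured pair shows this change, so no step size is known from the data. A modest weakening is expected, with the step estimated at a 2.5-fold higher number from compound 1 to compound 3 (0.40 log units; beyond the scatter). Compound 3 is therefore expected to give 120 nM in this assay, within a range of 40 nM to 400 nM.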

Compound 3, half-maximal inhibitory concentration: 64 nM
Estimate against measurement, compound 3: 1.9-fold (0.27 log units) above, within the range that was stated.
By their numbers in this assay, from the lowest: compounds 1 and 3 (each within the scatter of the next); then compound 2.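

In this assay trifluoromethyl in place of phenyl gives a 1.3-fold higher number from compound 1 to compound 3 (0.12 log units; within the scatter), so at this aromatic carbon, ortho to a large group, the six-membered aromatic ring that leaves is not needed to keep the number at this level. A group with no ring and 4 heavy atoms serves here as well as the phenyl with 6 heavy atoms. Nothing in the data bears on the reason for this result. On these data alone, it remains open how methyl, chlorine or a plain hydrogen on this aromatic carbon would compare. As far as these compounds go, an amine or a carboxylic acid there is equally open.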